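A few compounds are considered here, and "the series" means these few. Any claim that something is new, unique, unknown or untested is made for them only; others in the source may bear on it.

Measured in a functional assay on HBL-100 cells (Homo sapiens) for inhibition, read by sulforhodamine B assay, with a stated time of 48 h; on this read-out lower numbers stand for stronger inhibition of growth and higher numbers for weaker inhibition of growth:
Compound 1 `COC(=O)[C@@]1(C)CCC=C2[C@@H]1CC[C@@H](C)[C@]2(C)Cc1c[nH]c2ccc(C)cc12`: 18000 nM
Compound 2 `COC(=O)[C@@]1(C)CCC=C2[C@@H]1CC[C@@H](C)[C@]2(C)Cc1c[nH]c2ccc(Br)cc12`: 16000 nM
Compound 3 `COC(=O)[C@@]1(C)CC[C@@H]2C3=C1CC[C@@H](C)[C@]3(C)Cc1c2[nH]c2ccc(C)cc12`: 11000 nM

From compound 1 to compound 2 the change is bromo in place of methyl on an aromatic carbon, and the step it made is a 1.1-fold lower number from compound 1 to compound 2 (0.05 log units; within the scatter). Compound 3 carries a different core from compound 1; the difference between the two cores is not broken down here. The values of compound 3, compound 1 and compound 2 all lie within the scatter of one another, so no order among them can be read.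

Compound 4 `COC(=O)[C@@]1(C)CC[C@@H]2C3=C1CC[C@@H](C)[C@]3(C)Cc1c2[nH]c2ccc(Br)cc12` is not yet measured; it differs from compound 3 by bromo in place of methyl on an aromatic carbon. This is the same kind of change as from compound 1 to compound 2, though here the six-membered aromatic ring is part of a fused or bridged system of five rings rather than of two rings. Since the earlier step of this kind was a 1.1-fold lower number from compound 1 to compound 2 (0.05 log units; within the scatter), the expected step in this assay is a 1.1-fold lower number from compound 3 to compound 4 (0.04 log units; within the scatter), essentially nothing beyond the scatter. Compound 4 is therefore estimated at 10000 nM, with a likely range from 5000 nM to 20000 nM in this assay.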

Compound 4, concentration for 50% growth inhibition: 16000 nM
Estimate against measurement, compound 4: 1.6-fold (0.20 log units) below, within the range that was stated.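

In this assay, bromo in place of methyl on an aromatic carbon gives a 1.5-fold higher number from compound 3 to compound 4 (0.16 log units; within the scatter) on the core of compound 3, so the change has no readable effect there. Set beside the earlier step, the two cores do not separate: the same change on two cores in this assay, a 1.1-fold lower number (0.05 log units; within the scatter) from compound 1 to compound 2 and a 1.5-fold higher number (0.16 log units; within the scatter) from compound 3 to compound 4, 1.6-fold (0.21 log units) apart, within the scatter of two such steps. This shows that the change carried across these two cores without a detectable difference, but two steps, each within the scatter, do not show that it would be equally silent on other cores or in other assays.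

As far as these compounds go, it remains open whether an amine or a methoxy group at this aromatic carbon would move the number on either core. From the compounds shown here alone, it also remains open whether a carboxylic acid or an amide in place of the methyl ester would do so.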